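Trifluoromethyl for fluoro on a shared core: stability estimate

This account rests on a few compounds, and the source may have more. Where it says the series, first, only, none or still open, it means among the compounds named here.

Measured so far:
Compound 1, `COC(=O)N[C@H](C(=O)N1CCC[C@H]1C(=O)Nc1ccc([C@H]2CC[C@H](c3ccc(NC(=O)[C@@H]4CCCN4C(=O)[C@@H](NC(=O)OC)C(C)C)cc3)N2c2ccc(C(F)(F)F)cc2)cc1)C(C)C`: 58%
Compound 2, `COC(=O)N[C@H](C(=O)N1CCC[C@H]1C(=O)Nc1ccc([C@@H]2CC[C@@H](c3ccc(NC(=O)[C@@H]4CCCN4C(=O)[C@@H](NC(=O)OC)C(C)C)cc3)N2c2ccc(F)cc2)cc1)C(C)C`: 44%

In an ADME assay (liver) for metabolic stability, with Liver microsome (Homo sapiens) as the target, using microsomes, with a stated time of 30 min (on this read-out higher numbers stand for a more stable compound and lower numbers for a less stable compound), compound 2 stands lowest of the two numbers; compound 1 gives 58%, a difference that lies beyond the scatter. Compound 3, `COC(=O)N[C@H](C(=O)N1CCC[C@H]1C(=O)Nc1ccc([C@@H]2CC[C@@H](c3ccc(NC(=O)[C@@H]4CCCN4C(=O)[C@@H](NC(=O)OC)C(C)C)cc3)N2c2ccc(C(F)(F)F)cc2)cc1)C(C)C`, has not been measured. It differs from compound 2 by trifluoromethyl in place of fluoro on an aromatic carbon. Among the measured compounds shown here, no measured pair shows this change directly, so the step is judged from the two values alone. Compound 3 is expected to turn out more stable in this assay, about 55%, between 40% and 70%, an estimated step of a number 11 percentage points higher from compound 2 to compound 3 (beyond the scatter).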

Compound 3, percent of the compound remaining: 52%
Estimate against measurement, compound 3: 3 percentage points above, within the range that was stated.
By their numbers in this assay, from the lowest: compounds 2, 3 and 1 (each within the scatter of the next, the first and the last beyond it).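

In this assay, trifluoromethyl in place of fluoro gives a number 8 percentage points higher from compound 2 to compound 3 (within the scatter) and so does not clearly separate the two compounds at this position. The step in configuration at the two saturated ring carbons, a number 6 percentage points lower from compound 1 to compound 3 (within the scatter), also leaves the read-out inside the scatter. This second comparison isolates the stereocentres, and it rests on one point: the fact that compounds 1 and 3 differ only in the configuration as drawn.

On these data alone, whether fluoro and trifluoromethyl would compare in the same way on the configuration of compound 1 stays open. So does how a nitrile or an amine at this position would read in this assay.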